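This account rests on a few compounds, and the source may have more. Where it says the series, first, only, none or still open, it means among the compounds named here.

Measured compounds:
compound 1 `Nc1ncnc2c1c(Oc1cc(C(F)(F)F)ccn1)nn2[C@@H]1CCCC[C@H]1O` — > 2.41 h
compound 2 `Nc1ncnc2c1c(Oc1cc(C(F)(F)F)ccn1)nn2[C@H]1CC[C@@H](N)CC1` — > 2.41 h
compound 3 `Nc1ncnc2c1c(Oc1cc(C(F)(F)F)ccn1)nn2[C@H]1CC[C@H](CO)CC1` — > 2.41 h

In an ADME assay on microsomes from liver (Homo sapiens) for metabolic stability, read by LC-MS, using NADPH, with a stated time of 10 min, tested at 10 uM (on this read-out lower numbers stand for a shorter-lived compound and higher numbers for a longer-lived compound), compound 1 gives > 2.41 h, which is a limit of the assay and not a number. Compound 2 gives > 2.41 h, likewise a limit. Compound 3 gives > 2.41 h, again a limit. All three values sit at the limit of > 2.41 h in this assay, at which 3 of the 3 values shown sit, so compound 3 stands level with the other two as far as the read-out can tell. The steps among them are a step that the two limits leave unreadable from compound 1 to compound 2, a step that the two limits leave unreadable from compound 1 to compound 3 and a step that the two limits leave unreadable from compound 2 to compound 3; none gives a readable size.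

Compound 4 `Nc1ncnc2c1c(Oc1cc(C(F)(F)F)ccn1)nn2C1CCC(O)C1` is not yet measured. The change from compound 3 is 3-hydroxycyclopentyl in place of 4-(hydroxymethyl)cyclohexyl on an aromatic nitrogen. Going by the values given here, no measured step bears on this change with a readable size; the only evidence is that every variation of the ring group so far has left the half-life at the limit. The step that the limit leaves unreadable from compound 3 to compound 4 is therefore expected to lie within the scatter. Compound 4 is estimated at 3 h, with a range of 1.2 h to 8 h, most likely reported again as a limit.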

Compound 4, half-life: > 2.41 h
Compound 4: no number, only a limit (the forecaster's own chance of this, stated with the estimate: 70%); the middle value is on the limit's open side.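

Compound 4 gives only a limit, as do compound 1, compound 2 and compound 3, so no step among these four can be read in this assay: the limit of > 2.41 h in this assay, at which 4 of the 4 values shown sit.

The compounds shown leave open what half-life any of the four has as a number, and whether their ring groups on the aromatic nitrogen differ at all.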